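This account rests on a few compounds, and the source may have more. Where it says the series, first, only, none or still open, it means among the compounds named here.

Measured compounds and their results in a functional assay on K562 cells (Homo sapiens) for antiproliferative activity, read by MTT assay, with a stated time of 48 h; on this read-out higher numbers stand for weaker inhibition and lower numbers for stronger inhibition:
compound 1 `Cn1c(N)c(-c2nc3ccccc3[nH]2)c2nc(C#N)c(C#N)nc21` — > 50000 nM, a limit of the assay and not a number.
compound 2 `N#Cc1nc2c(-c3nc4ccccc4[nH]3)c(N)n(CCO)c2nc1C#N` — > 50000 nM, a limit of the assay and not a number.
compound 3 `CCCCn1c(N)c(-c2nc3ccccc3[nH]2)c2nc(C#N)c(C#N)nc21` — > 50000 nM, a limit of the assay and not a number.

Every result in this set is a limit, so compound 1 cannot be placed relative to the other two beyond noting that all sit together at the limit of > 50000 nM in this assay, at which 3 of the 3 values shown sit. The steps a step that the two limits leave unreadable from compound 1 to compound 2 and a step that the two limits leave unreadable from compound 1 to compound 3 are accordingly of unreadable size, as is a step that the two limits leave unreadable from compound 2 to compound 3.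

Compound 4 `N#Cc1nc2c(-c3nc4ccccc4[nH]3)c(N)n(CCCO)c2nc1C#N` differs from compound 1 by 2-hydroxyethyl in place of hydrogen on a saturated chain carbon bound to an aromatic nitrogen. The measured steps that bear on it are the two starting from compound 1, and neither is readable; nothing among them shows whether any substituent on that chain carbon moves the read-out away from the limit. With no readable step in either direction, no change beyond the scatter is expected for a step that the limit leaves unreadable from compound 1 to compound 4, and compound 4 is expected once more to sit at the limit. The estimate for compound 4 in this assay is 70000 nM, within 30000 nM to 200000 nM.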

Compound 4, half-maximal inhibitory concentration: > 50000 nM
Compound 4: only a limit was reported; the forecaster's own chance of this, stated with the estimate: 85%; the middle value does not contradict the limit.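

In this assay compound 4 gives only a limit of the assay, as do compounds 1, 2 and 3, so no step among these four can be read: the limit of > 50000 nM in this assay, at which 4 of the 4 values shown sit.

On these data alone, whether any chain on the aromatic nitrogen of the shared core moves the read-out away from that limit remains open.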